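This account rests on a few compounds, and the source may have more. Where it says the series, first, only, none or still open, it means among the compounds named here.

In a functional assay on the whole organism (artery, strain albino) with Rattus norvegicus as the target, with a stated time of 60 min, at a dose of 10 mg/kg by the oral route (a lower number here means less inhibition, a higher number more inhibition at the dose given (going by the name of the read-out)), compound 1 `COc1ccc(C2N=C(SCc3ccccc3Cl)NC(C)=C2C(=O)Nc2ccc(F)cc2)cc1OC` gives 11.8%. Compound 2 `COc1ccc(C2N=C(SCc3cccc(Cl)c3)NC(C)=C2C(=O)Nc2ccc(F)cc2)cc1OC` differs from it by the change (3-chlorophenyl in place of 2-chlorophenyl on a saturated chain carbon bound to a sulfur), and in this assay compound 2 gives 8.2%, so the change made the step of a number 3.6 percentage points lower from compound 1 to compound 2 (within the scatter). Compound 3 `COc1ccc(C2N=C(SCc3ccccc3Cl)NC(C)=C2C(=O)Nc2ccc(Br)cc2)cc1` carries a different core, and the difference between the two cores is not broken down here; in this assay compound 3 gives 6.7%. Compound 4 `COc1ccc(C2N=C(SCc3cccc(Cl)c3)NC(C)=C2C(=O)Nc2ccc(Br)cc2)cc1` has not yet been measured. Among the measured compounds shown here, it differs from compound 3 by the change (3-chlorophenyl in place of 2-chlorophenyl on a saturated chain carbon bound to a sulfur), the same change as the one from compound 1 to compound 2, made at the same place. The step that the estimate below means, a number 1.7 percentage points lower from compound 3 to compound 4 (within the scatter), is expected to be of about the same size as the earlier one and again within the scatter. That expectation rests on compound 3, which gives 6.7%, and on the step of a number 3.6 percentage points lower from compound 1 to compound 2 (within the scatter). In this assay compound 4 is therefore expected to give 5%, most likely between 0% and 14%.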

Compound 4, a percentage reported as inhibition, in the whole organism at one dose (the size of the read-out at that dose, not a potency): 15.4%
Compound 4: middle estimate off by 10.4 percentage points, on the low side, outside the stated range (above it).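

Putting 3-chlorophenyl in place of 2-chlorophenyl, on the saturated chain carbon bound to a sulfur, gives in this assay a number 8.7 percentage points higher from compound 3 to compound 4 (within the scatter). Set beside the same change on the other core, this step cannot be told apart from the earlier one: the same change on two cores in this assay, a number 3.6 percentage points lower (within the scatter) from compound 1 to compound 2 and a number 8.7 percentage points higher (within the scatter) from compound 3 to compound 4, 12.3 percentage points apart, within the scatter of two such steps. This shows no sign that the core alters what the change does, but it does not prove that the change carries over unaltered from one core to the other, as both steps and the gap between them lie inside the scatter, where a modest real effect would stay hidden.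

The compounds shown carry only 2-chlorobenzyl and 3-chlorobenzyl on the sulfur, and each is read at a single dose, which says nothing about potency. Going by these compounds, what a plain benzyl group, a longer chain such as phenethyl, or a chain ending in an amine or a carboxylic acid would give on either core remains open.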